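Replacing hydroxy by methyl in compound 2

The compounds below may be only part of what the source reports. "The series", "measured", "known", "first", "only" and "open" are said of these compounds alone.

In a functional assay on HeLa cells (Homo sapiens) for antiproliferative activity, read by MTT assay, with a stated time of 48 h (on this read-out higher numbers stand for weaker inhibition and lower numbers for stronger inhibition), compound 1 `COc1ccc(-c2cncc3[nH]c(=O)n(Cc4cc(OC)c(OC)c(OC)c4)c23)cc1` gives > 20000 nM, which is a limit of the assay and not a number. Going by the values given here, compound 2 `COc1ccc(-c2cc3c(cn2)[nH]c(=O)n3-c2cc(OC)c(OC)c(OC)c2)cc1O` gives 490 nM in this assay, the only true number so far.

Compound 3 `COc1ccc(-c2cc3c(cn2)[nH]c(=O)n3-c2cc(OC)c(OC)c(OC)c2)cc1C` has methyl in place of hydroxy on an aromatic carbon, ortho to a methoxy group and meta to a large group: methyl in place of hydroxy on an aromatic carbon. The same difference reads 3-hydroxy-4-methoxyphenyl to 4-methoxy-3-methylphenyl.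

Among the compounds with values here, no measured pair isolates this change, so the expectation is anchored only on compound 2 at 490 nM. A shift no larger than the usual scatter is expected in this assay, with no firm direction. The expected step is a 1.2-fold higher number from compound 2 to compound 3 (0.09 log units; within the scatter). For compound 3 the estimate is 600 nM, with an expected range of 150 nM to 2500 nM.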

Compound 3, half-maximal inhibitory concentration: 1410 nM
Beside the measured number, compound 3's estimate is 2.4-fold (0.37 log units) below it; measured number inside the range.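

In this assay, the one-place change gives a 2.9-fold higher number from compound 2 to compound 3 (0.46 log units; beyond the scatter), so the 3-hydroxy-4-methoxyphenyl and 4-methoxy-3-methylphenyl groups are not interchangeable at this position, though the step is modest. Going by these compounds alone, this is the first pair that isolates a single place, and it shows that the aromatic carbon ortho to a methoxy group responds to methyl in place of hydroxy. Compound 3 still gives a true number, 1410 nM, so hydroxy at this position is not needed for a measurable value in this assay.

From the compounds shown here alone, whether the step follows from losing hydroxy or from adding methyl stays open, and an amine or a methoxy group at the same carbon would bear on that question. Nothing in the available evidence bears on the reason for this step.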